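Changing the group on the sulfonyl sulfur

The source may report more compounds than this note shows. Statements on the series, on what has been measured and on what is new or still open speak of the compounds shown alone.

The series is read in an ADME assay on Vero cells (Chlorocebus sabaeus) for cytotoxicity, read by MTT assay; on this read-out lower numbers stand for higher toxicity in this test and higher numbers for lower toxicity in this test. Compound 1 (`Cn1nc(C(F)(F)F)cc1C(=O)Nc1ccc(S(=O)(=O)N2CCCCCC2)cc1`) gives > 300000 nM, which is a limit of the assay. Compound 3 (`Cn1nc(C(F)(F)F)cc1C(=O)Nc1ccc(S(=O)(=O)OC2CCCCC2)cc1`) gives > 300000 nM, also a limit and not a number. Compound 3 therefore stands at the limit of > 300000 nM in this assay, at which 2 of the 3 values shown sit. Compound 2 (`Cn1nc(C(F)(F)F)cc1C(=O)Nc1ccc(S(=O)(=O)N2CCCCCCC2)cc1`) gives a measured 16000 nM.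

Compound 4 (`Cn1nc(C(F)(F)F)cc1C(=O)Nc1ccc(S(=O)(=O)N2CCC(O)CC2)cc1`) differs from compound 3 by 4-hydroxypiperidin-1-yl in place of cyclohexyloxy on a sulfonyl sulfur. The group stays on the sulfonyl sulfur, and a six-membered non-aromatic ring remains there. Two large measured steps bear on this: an at least 18-fold lower number from compound 1 to compound 2 (1.27 log units; beyond the scatter) and an at least 18-fold higher number from compound 2 to compound 3 (1.27 log units; beyond the scatter). Both involve the eight-membered ring of compound 2, which compound 4 lacks. The third step, a step that the two limits leave unreadable from compound 1 to compound 3, gives no size. No step beyond the scatter is therefore expected in this assay, and any readable move would be towards a lower number. The expected step is a number no higher from compound 3 to compound 4 (the limit leaves the size open). For compound 4 the estimated value is 300000 nM, with an expected range from 100000 nM to 600000 nM.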

Compound 4, half-maximal cytotoxic concentration: 274000 nM
Estimate against measurement, compound 4: 1.1-fold (0.04 log units) above; the range from low to high includes it.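

In this assay, within the data shown here, compound 4 gives 274000 nM, and a 17-fold higher number from compound 2 to compound 4 (1.23 log units; beyond the scatter) leaves compound 2 with the only low number among the four compounds. With 4-hydroxypiperidin-1-yl on the sulfonyl sulfur, the readable floors are an at least 1.0-fold lower number from compound 3 to compound 4 (0.03 log units; that floor lies within the scatter) and an at least 1.0-fold lower number from compound 1 to compound 4 (0.03 log units; that floor lies within the scatter), so neither comparison shows a move beyond the scatter. Compound 1 and compound 3 each give a limit and not a number: the limit of > 300000 nM in this assay, at which 2 of the 4 values shown sit.

Open, on these data alone, is whether an amine or a carboxylic acid in place of the hydroxy group of 4-hydroxypiperidin-1-yl would keep the number of compound 4. Also open, as far as these compounds go, is whether plain piperidin-1-yl would read like compound 4, and whether a hydroxy group on the eight-membered ring of compound 2 would raise its number in this assay.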